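Swapping the aryl group on a cytotoxic diarylidene scaffold

This account rests on a few compounds, and the source may have more. Where it says the series, first, only, none or still open, it means among the compounds named here.

The series rests on a shared core carrying two arylidene arms, tested in a functional assay on HeLa cells (Homo sapiens) for cytotoxicity, read by CCK-8 assay, with a stated time of 72 h; a higher number here means a weaker inhibitor, a lower number a stronger inhibitor. Compound 1 `COc1ccccc1/C=c1/[nH]c(=O)/c(=C\c2ccccc2OC)[nH]c1=O` bears two 2-methoxyphenyl arms on an unsubstituted core. In this assay compound 1 gave "not active" (no number reported). Compound 3 `C=CCn1c(=O)/c(=C\c2cc(OC)c(OC)c(OC)c2)[nH]c(=O)/c1=C\c1cccc(Br)c1` carries an allyl group on the core with 3,4,5-trimethoxyphenyl and 3-bromophenyl arms. In this assay compound 3 gave "not active" (no number reported). Among the measured compounds shown here, compound 2 `C=CCn1c(=O)/c(=C\c2cc(F)ccc2C)[nH]c(=O)/c1=C\c1ccccc1OC`, also with the allyl group and a 2-methoxyphenyl arm, is the only member of the set with a reported number: in this assay compound 2 gave 2900 nM, while the two other entries show no number at all.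

Compound 4 `C=CCn1c(=O)/c(=C\c2ccccc2Cl)[nH]c(=O)/c1=C\c1ccccc1OC` differs from compound 2 in one place: 2-chlorophenyl in place of 5-fluoro-2-methylphenyl on a double-bonded chain carbon bound to an aromatic carbon. For the measured compounds named here, no measured pair of this kind exists here, so there is no comparison to lean on. With compound 2 at 2900 nM as the only anchor, the step from compound 2 to compound 4 is expected to be small, a 1.4-fold higher number from compound 2 to compound 4 (0.14 log units; within the scatter), with no clear direction beyond the scatter. Compound 4 is estimated at 4000 nM, within 1500 nM to 15000 nM.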

Compound 4, half-maximal inhibitory concentration: 5100 nM
Estimate against measurement, compound 4: 1.3-fold (0.11 log units) below, within the range that was stated.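

In this assay the change to 2-chlorophenyl on a double-bonded chain carbon bound to an aromatic carbon is read as a 1.8-fold higher number from compound 2 to compound 4 (0.25 log units; within the scatter) and so does not separate the two compounds. Among the compounds shown here, this is the first comparison in the set between compounds that differ in one place, and it shows that, with the allyl group and the 2-methoxyphenyl arm held fixed, these two aryl groups cannot be told apart in this assay. No measurement shown here gives a reason for this result.

As far as these compounds go, whether an aryl group carrying an amine or a carboxylic acid at this place would give a step beyond the scatter remains open. So does whether a longer chain in place of the allyl group on the core would change the number.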